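Compound 3: a new group on the nitrogen

A few compounds are considered here, and "the series" means these few. Any claim that something is new, unique, unknown or untested is made for them only; others in the source may bear on it.

Compound 1 `O=C(Nc1ccc(NC2CCCCC2)cc1Cl)c1cc(Cl)ccc1O`: 68300 nM
Compound 2 `CC1(ON(c2ccc(NC(=O)c3cc(Cl)ccc3O)c(Cl)c2)C2(C)CCCC2)CCCC1`: 18000 nM

Compound 1 holds the higher of the two numbers in an ADME assay on A549 cells (Homo sapiens) for cytotoxicity, read by resazurin assay, with a stated time of 48 h (a higher number here means that more compound is tolerated, a lower number that less compound is tolerated), and its gap to compound 2 lies beyond the usual scatter. Compound 3 `O=C(Nc1ccc(NCc2ccc(Br)cc2)cc1Cl)c1cc(Cl)ccc1O`, not yet measured, keeps the core of compound 1 but carries 4-bromobenzyl in place of cyclohexyl on a nitrogen on an aromatic ring. Within the data shown here, no two measured compounds differ in only one place, so no measured step can guide this change, and any expectation stays rough. Among the measured compounds shown here, the only other reference is compound 2 at 18000 nM, so a modest move towards less compound tolerated seems more likely than a rise. The expected step is a 2.3-fold lower number from compound 1 to compound 3 (0.36 log units; beyond the scatter). For compound 3 the estimated value is 30000 nM, with an expected range from 9000 nM to 90000 nM.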

Compound 3, half-maximal cytotoxic concentration: 40900 nM
Compound 3: the middle estimate sits 1.4-fold (0.13 log units) below what was measured; measured number inside the range.
By their numbers in this assay, from the lowest: compound 2; then compounds 3 and 1 (each within the scatter of the next).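

In this assay, among these compounds, this is the first comparison of two compounds that differ in only one place, and a 1.7-fold lower number from compound 1 to compound 3 (0.22 log units; within the scatter) stays within the usual scatter. On this nitrogen on an aromatic ring, cyclohexyl and 4-bromobenzyl therefore cannot be told apart in this read-out. That holds even though the change swaps a non-aromatic ring of carbon for an aromatic one and brings in a bromine. Nothing measured here accounts for this result.

Going by these compounds, it remains open whether a very different group on the same nitrogen, such as a carboxylic acid or a longer chain, would move the number beyond the scatter. On these data alone, it is also open what the bromine contributes, a question that a plain benzyl group at this place would address.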